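A few compounds are considered here, and "the series" means these few. Any claim that something is new, unique, unknown or untested is made for them only; others in the source may bear on it.

Measured so far in an ADME assay on microsomes from liver (Rattus norvegicus) for metabolic stability, read by LC-MS, using NADPH, at 37 degrees C; on this read-out lower numbers stand for a shorter-lived compound and higher numbers for a longer-lived compound:

- compound 1 `Cc1ccccc1-c1nc(CN2CCC(C(=O)NCCCN3CC(C)(C)CC(C)(C)C3)CC2)c(C)o1`: 0.095 h
- compound 2 `Cc1oc(-c2ccc(Cl)cc2)nc1CN1CCC(C(=O)NCCCN2C[C@H](C)C[C@H](C)C2)CC1`: > 0.5 h (a limit)
- compound 3 `Cc1ccccc1-c1nc(CN2CCC(C(=O)NCCCN3[C@H](C)CCC[C@@H]3C)CC2)c(C)o1`: > 0.5 h (a limit)

Only compound 1 has a real number here, while the entries for compound 2 and compound 3 are limits of the assay. Compound 2 stands at the limit of > 0.5 h in this assay, at which 2 of the 3 values shown sit, and this is a limit, not a number.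

Compound 4 `Cc1oc(-c2c(F)cccc2F)nc1CN1CCC(C(=O)NCCCN2C[C@H](C)C[C@H](C)C2)CC1` differs from compound 2 in one place, with 2,6-difluorophenyl in place of 4-chlorophenyl on an aromatic carbon. For the measured compounds named here, the only measured step, an at least 5.2-fold higher number from compound 1 to compound 3 (0.72 log units; beyond the scatter), lies beyond the scatter, but it replaces a group on a saturated chain carbon and not the group that changes here. Going by the values given here, no measured step covers the change from 4-chlorophenyl to 2,6-difluorophenyl, so no step beyond the scatter is expected in this assay, in either direction.

The estimated change is a number no higher from compound 2 to compound 4 (the limit leaves the size open).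

Compound 4 is expected at 0.5 h, with an estimated range from 0.2 h to 1 h.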

Compound 4, half-life: 0.35 h
Beside the measured number, compound 4's estimate is 1.4-fold (0.15 log units) above it, within the range that was stated.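

For the compounds shown here, on an aromatic carbon of a five-membered aromatic ring with 1 nitrogen and 1 oxygen, 2,6-difluorophenyl in place of 4-chlorophenyl gives the first step at this position in this assay: an at least 1.4-fold lower number from compound 2 to compound 4 (0.15 log units; that floor lies within the scatter). Compound 4, at 0.35 h, carries a real number, so this aryl position now has one measured value to work from, although the true size of the change could still lie within the scatter or beyond it. Compound 2 has a limit and not a number here: the limit of > 0.5 h in this assay, at which 2 of the 4 values shown sit.

From the compounds shown here alone, how far the real half-life of compound 2 lies from its limit stays open. Also open, going by these compounds, is how a plain phenyl or a 4-methoxyphenyl would read at this position in this assay.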